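The source may report more compounds than this note shows. Statements on the series, on what has been measured and on what is new or still open speak of the compounds shown alone.

The measured compounds:

Compound 1 `CC1=CC[C@H](C(C)(C)NC(=S)N/N=C/c2ccccc2)CC1` gives 1300 nM in a functional assay on PC-3 cells (Homo sapiens) for inhibition, read by sulforhodamine B assay, with a stated time of 48 h; on this read-out lower numbers stand for stronger inhibition of growth and higher numbers for weaker inhibition of growth.
Compound 2 `CC1=CC[C@H](C(C)(C)NC(=S)N/N=C/c2ccccc2O)CC1` gives a reading that is a limit of the assay, < 40 nM.
Compound 3 `CC1=CC[C@H](C(C)(C)NC(=S)N/N=C/c2ccccc2Cl)CC1` gives 50 nM.

Compound 3 has the lowest of the two numbers shown, and the nearest number, that of compound 1, lies well apart: a 26-fold lower number from compound 1 to compound 3 (1.41 log units; beyond the scatter). The reading of compound 2 is a limit (the limit of < 40 nM in this assay, at which 1 of the 3 values shown sits). Between compound 2 and compound 3 the change is an at least 1.2-fold higher number from compound 2 to compound 3 (0.09 log units; that floor lies within the scatter), so no order between these two can be set.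

Compound 4 `CC1=CC[C@H](C(C)(C)NC(=S)N/N=C/c2ccccc2[N+](=O)[O-])CC1` differs from compound 3 in one place: nitro in place of chloro on an aromatic carbon. Within the data shown here, no measured step swaps chloro for nitro, so the expectation rests on neighbouring steps. Putting chloro or hydroxy in place of hydrogen at this carbon gave large drops, a 26-fold lower number from compound 1 to compound 3 (1.41 log units; beyond the scatter) and an at least 32-fold lower number from compound 1 to compound 2 (1.51 log units; beyond the scatter), while exchanging hydroxy for chloro gave an at least 1.2-fold higher number from compound 2 to compound 3 (0.09 log units; that floor lies within the scatter). Two different groups at this carbon gave numbers close to each other, and a third group is expected to behave similarly. For compound 4 the estimated step is a 1.2-fold higher number from compound 3 to compound 4 (0.08 log units; within the scatter), within the scatter. Compound 4 is thus expected to give about 60 nM, with a likely range from 25 nM to 200 nM.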

Compound 4, concentration for 50% growth inhibition: 1700 nM
The estimate for compound 4 lay 28-fold (1.45 log units) below the measured number, outside the stated range (above it).
By their numbers in this assay, from the lowest: compound 3; then compounds 1 and 4 (each within the scatter of the next). At a limit, below all of these: compound 2.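

At this aromatic carbon, nitro does not go the way of chloro or hydroxy: a 34-fold higher number from compound 3 to compound 4 (1.53 log units; beyond the scatter) and an at least 42-fold higher number from compound 2 to compound 4 (1.62 log units; beyond the scatter) show large rises, while a 1.3-fold higher number from compound 1 to compound 4 (0.12 log units; within the scatter) stays within the scatter in this assay. So the large drops seen earlier do not come from placing just any group here, since compound 4 reads like compound 1, which carries only hydrogen at this carbon, and the gain belongs to chloro and hydroxy, not to substitution as such. The step from compound 2 starts from a reading that is a limit: the limit of < 40 nM in this assay, at which 1 of the 4 values shown sits.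

Nothing shown explains why nitro parts from chloro and hydroxy. On these data alone, whether an amine, a methoxy group or a fluorine at this carbon would read like chloro and hydroxy or like nitro remains open.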